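The source may hold more compounds than are shown below. What is called first, only, known or untested is meant among the compounds shown, and "the series" means these compounds.

Working notes on the series. Compound 1 `COc1ccc(F)cc1CNCCCNc1ccnc2cc(Cc3ccc(C#N)cc3)ccc12` in a physicochemical assay for acid dissociation, gives 9.47, level with compound 2 `COc1cccc(CNCCCNc2ccnc3cc(Cc4ccc(C#N)cc4)ccc23)c1O` at 9.47 and with compound 3 `COc1cccc(CNCCCNc2ccnc3cc(-c4cc(C(F)(F)F)cc(C(F)(F)F)c4)ccc23)c1O` at 9.47; all three sit together within the scatter. Among the measured compounds shown here, the one measured step, no change at the digits printed from compound 1 to compound 2 (within the scatter), replaces the benzyl group on the amine nitrogen and leaves this assay untouched. Compound 4 `COc1ccc(F)cc1CNCCCNc1ccnc2cc(-c3cccc4ccccc34)ccc12` differs from compound 1 at the other end of the core: naphthalen-1-yl in place of 4-cyanobenzyl on an aromatic carbon. For the measured compounds named here, no measured step alters this position, but compound 2 and compound 3, which carry different groups there, read the same value, so no step beyond the scatter is expected in this assay. Compound 4 is therefore estimated at 9.47, expected between 9.1 and 9.8. The expected step is no change at the digits printed from compound 1 to compound 4 (within the scatter).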

Compound 4, acid dissociation constant: 9.47
The estimate for compound 4 equals the measured number at the digits printed; low and high end bracket the measured number.
By their numbers in this assay, from the lowest: compounds 1, 2, 3 and 4 (each within the scatter of the next).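

In this assay, naphthalen-1-yl in place of 4-cyanobenzyl gives a direct step at this position, reading no change at the digits printed from compound 1 to compound 4 (within the scatter) with the 5-fluoro-2-methoxyphenyl group held constant. The change removes the nitrile and its hydrogen-bond acceptor and brings a second six-membered aromatic ring of carbon only, yet the two compounds stay level. No evidence is available that accounts for this result. As far as these compounds go, whether an aliphatic amine or a carboxylic acid on this aromatic carbon would also leave the reading level remains open.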